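Swapping Bromo for Phenyl on the Shared Core

The compounds below may be only part of what the source reports. "The series", "measured", "known", "first", "only" and "open" are said of these compounds alone.

Measured compounds:
compound 1 `O=C(CCCCCCc1ccccc1)c1nc(C(=O)C(F)(F)F)co1` gives 123 nM
compound 2 `COc1coc(C(=O)CCCCCCc2ccccc2)n1` gives the assay limit > 10000 nM
compound 3 `O=C(CCCCCCc1ccccc1)c1nc(Br)co1` gives the assay limit > 10000 nM

Three compounds share one core and differ only in the group on one aromatic carbon of the five-membered ring. Among the measured compounds shown here, in an assay on HEK-293T cells for inhibition of diacylglycerol lipase-alpha (Homo sapiens), read by colorimetric assay (a higher number here means a weaker inhibitor, a lower number a stronger inhibitor), compound 1 is the only one with a real number. Compound 2 reaches just the limit of the assay, so its value is a boundary, not a measurement. Compound 3 stands at that same limit, together with compound 2 and without any number of its own. The step of an at least 81-fold higher number from compound 1 to compound 2 (1.91 log units; beyond the scatter) and the step of an at least 81-fold higher number from compound 1 to compound 3 (1.91 log units; beyond the scatter) both show a large loss once the (trifluoromethyl)carbonyl group is replaced. The comparison a step that the two limits leave unreadable from compound 2 to compound 3 cannot be sized, because both values sit at the limit of > 10000 nM in this assay, at which 2 of the 3 values shown sit.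

Compound 4 `O=C(CCCCCCc1ccccc1)c1nc(-c2ccccc2)co1` has not been measured. The change from compound 3 is phenyl in place of bromo on an aromatic carbon. For the measured compounds named here, none of the measured steps involves a phenyl group, so no step bears on it directly; the two sized steps only show how much is lost when the (trifluoromethyl)carbonyl is gone. The expectation is therefore that compound 4 stays weak, with a step of an at least 1.2-fold lower number from compound 3 to compound 4 (0.09 log units; that floor lies within the scatter) that is not readable against a limit. Compound 4 is estimated at 8000 nM, within 1000 nM to 50000 nM.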

Compound 4, half-maximal inhibitory concentration: 8710 nM
Estimate against measurement, compound 4: 1.1-fold (0.04 log units) below; the measured number falls inside the stated range.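

Phenyl, with six heavy atoms in place of the single bromine, gives the first real number at this position without the (trifluoromethyl)carbonyl group, so that loss can now be sized rather than merely bounded: a 71-fold higher number from compound 1 to compound 4 (1.85 log units; beyond the scatter). The steps of an at least 1.1-fold lower number from compound 3 to compound 4 (0.05 log units; that floor lies within the scatter) and an at least 1.1-fold lower number from compound 2 to compound 4 (0.05 log units; that floor lies within the scatter) do not show phenyl to be better than bromo or methoxy, and their true sizes cannot be read because compounds 2 and 3 give only a limit: the limit of > 10000 nM in this assay, at which 2 of the 4 values shown sit. Adding a whole aromatic ring of carbon here therefore does not bring back what compound 1 has, and among these four compounds only compound 1 stands apart from the rest.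

The compounds shown leave open which part of the (trifluoromethyl)carbonyl group matters, since a plain acetyl group, a nitrile or an ester at this carbon would separate the carbonyl from the trifluoromethyl. They also leave open whether a phenyl ring carrying a further group, such as a carboxylic acid or an amine, would behave differently from the bare phenyl of compound 4.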